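The compounds below may be only part of what the source reports. "The series", "measured", "known", "first", "only" and "open" are said of these compounds alone.

Measured in a functional assay on DU-145 cells (Homo sapiens) for antiproliferative activity, read by MTT assay, with a stated time of 48 h; on this read-out lower numbers stand for stronger inhibition and higher numbers for weaker inhibition:
- Compound 1 `COc1ccccc1-n1cc(COC(=O)/C(C)=C/CC/C(C)=C/CC/C(C)=C/CC[C@@H]2[C@@]3(C)CCC(=O)C(C)(C)[C@H]3CC[C@@]2(C)O)nn1`: > 150000 nM
- Compound 2 `C/C(=C\CC/C(C)=C/CC[C@@H]1[C@@]2(C)CCC(=O)C(C)(C)[C@H]2CC[C@@]1(C)O)CC/C=C(\C)C(=O)OCc1cn(-c2ccccc2[N+](=O)[O-])nn1`: > 150000 nM
- Compound 3 `C/C(=C\CC/C(C)=C/CC[C@@H]1[C@@]2(C)CCC(=O)C(C)(C)[C@H]2CC[C@@]1(C)O)CC/C=C(\C)C(=O)OCc1cn(-c2cccc([N+](=O)[O-])c2)nn1`: > 150000 nM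

Each of these entries is a limit of the assay and not a true number. Compound 3 therefore has no exact place on the scale, and all that is shown for it is the limit of > 150000 nM in this assay, at which 3 of the 3 values shown sit.

The next compound is compound 4 `COc1ccc(-n2cc(COC(=O)/C(C)=C/CC/C(C)=C/CC/C(C)=C/CC[C@@H]3[C@@]4(C)CCC(=O)C(C)(C)[C@H]4CC[C@@]3(C)O)nn2)cc1`, which has 4-methoxyphenyl in place of 3-nitrophenyl on an aromatic nitrogen of the five-membered ring: 4-methoxyphenyl in place of 3-nitrophenyl on an aromatic nitrogen.

Within the data shown here, three measured steps bear on this change. Among the measured compounds shown here, the first is a step that the two limits leave unreadable from compound 1 to compound 3, which swaps the same kind of aromatic group. The second is a step that the two limits leave unreadable from compound 2 to compound 3, and the third is a step that the two limits leave unreadable from compound 1 to compound 2. None of them has a readable size, so they offer no direction to carry over.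

Compound 1 is the measured compound that also has a methoxy group on this aromatic ring, and it too gives only a limit, > 150000 nM. On that basis, compound 4 is expected to be reported most likely as a limit as well.

The estimated step in this assay is a number no higher from compound 3 to compound 4 (the limit leaves the size open), and no clear change in either direction is expected. For compound 4 the estimate is 150000 nM, with an expected range from 60000 nM to 300000 nM.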

Compound 4, half-maximal inhibitory concentration: 135000 nM
The estimate for compound 4 lay 1.1-fold (0.05 log units) above the measured number; the range from low to high includes it.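

In this assay, compound 4, with its 4-methoxyphenyl group on the aromatic nitrogen of the five-membered ring, is the only compound shown that gives a true number, 135000 nM, which makes an at least 1.1-fold lower number from compound 3 to compound 4 (0.04 log units; that floor lies within the scatter) readable as a floor. The same kind of floor now holds for the swap from a nitro-bearing ring, with an at least 1.1-fold lower number from compound 2 to compound 4 (0.04 log units; that floor lies within the scatter), and for the methoxy-bearing pair, with an at least 1.1-fold lower number from compound 1 to compound 4 (0.04 log units; that floor lies within the scatter). Among these compounds, the steps among compound 1, compound 2 and compound 3 cannot be read, so these floors are the only readable steps, none of them goes beyond the scatter, and limits still dominate the picture: the limit of > 150000 nM in this assay, at which 3 of the 4 values shown sit.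

As far as these compounds go, it stays open whether true numbers for compound 1, compound 2 and compound 3 would lie close to that of compound 4 or far from it, so the real size of this change is unknown. Also open, from the compounds shown here alone, is what an unsubstituted phenyl, a 4-nitrophenyl, or a phenyl ring carrying an amine or a carboxylic acid would give on this same ring nitrogen.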